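Swapping methylsulfanyl for methoxy in compound 1

The source may report more compounds than this note shows. Statements on the series, on what has been measured and on what is new or still open speak of the compounds shown alone.

Values in a functional assay on HeLa cells (Homo sapiens) for antiproliferative activity, read by sulforhodamine B assay, with a stated time of 48 h; a lower number here means a stronger inhibitor, a higher number a weaker inhibitor:
Compound 1 `CSc1ccc(N(C)c2ncnc3occ(C)c23)cc1`: 15.7 nM
Compound 2 `CCN(c1ccc(OC)cc1)c1ncnc2occ(C)c12`: 15.8 nM
Compound 3 `CCCCN(c1ccc(OC)cc1)c1ncnc2occ(C)c12`: 111 nM
Compound 4 `COc1ccc(N(C)c2ncnc3occ(C)c23)cc1`: not yet measured

In this assay compound 1 gives 15.7 nM, which is within the scatter of compound 2 at 15.8 nM. The two share the low end of the series, and compound 3 stands clearly higher at 111 nM. Compound 4 takes methoxy in place of methylsulfanyl on an aromatic carbon. Going by the values given here, no measured step makes this exchange. Among the compounds with values here, the only step available, a 7.0-fold higher number from compound 2 to compound 3 (0.85 log units; beyond the scatter), is modest and lies on the chain at the nitrogen, so it bears on the exchange only indirectly. More telling is compound 2, which already carries methoxy and gives 15.8 nM. On that basis no change beyond the scatter is expected in this assay. The expected step is a 1.2-fold lower number from compound 1 to compound 4 (0.08 log units; within the scatter). The estimate for compound 4 is 13 nM, with an expected range from 5 nM to 35 nM.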

Compound 4, half-maximal inhibitory concentration: 9.5 nM
Estimate against measurement, compound 4: 1.4-fold (0.14 log units) above, and the stated range covers the measured number.
By their numbers in this assay, from the lowest: compounds 4, 1 and 2 (each within the scatter of the next); then compound 3.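

In this assay, the exchange of methylsulfanyl for methoxy on an aromatic carbon, para to a large group, gives a 1.7-fold lower number from compound 1 to compound 4 (0.22 log units; within the scatter) and so shows directly that this position holds either group with no change beyond the scatter. On the chain at the nitrogen, with methoxy held in place, methyl and ethyl stay level in a 1.7-fold lower number from compound 2 to compound 4 (0.22 log units; within the scatter) while the butyl compound stands apart in a 12-fold lower number from compound 3 to compound 4 (1.07 log units; beyond the scatter) and this is the largest step in the series. Nothing measured here accounts for either result.

The compounds shown leave open how a hydroxyl, an amino group or a chlorine atom would fare on this aromatic carbon. They also leave open whether methylsulfanyl stays level with methoxy when the methyl on the nitrogen gives way to ethyl or butyl, or to a bare hydrogen.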